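Notes on compound 4 against the measured set

The compounds below may be only part of what the source reports. "The series", "measured", "known", "first", "only" and "open" are said of these compounds alone.

Of the compounds shown here, three have been measured in a functional assay on PANC-1 cells (Homo sapiens) for inhibition, read by MTT assay, with a stated time of 24 h, tested at 10 uM; a lower number here means less inhibition, a higher number more inhibition at the concentration tested (going by the name of the read-out). Compound 2 `CCOc1cc(=O)n(CCCO)c2c1CC(CC=C(C)C)C(C)(C)C2` gives 66.5%, the highest of the three. Compound 1 `CC(C)=CCC/C(C)=C/CC1Cc2c(O)cc(=O)n(CCCO)c2CC1(C)C` gives 28.7%, and compound 3 `CC(C)=CCC1Cc2c(OCCCNS(=O)(=O)c3ccc(Cl)cc3)cc(=O)n(CCCO)c2CC1(C)C` gives 24.7%, both well below compound 2 and both beyond the scatter.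

Compound 4 `COc1ccccc1NC(=O)Oc1cc(=O)n(CCCO)c2c1CC(CC=C(C)C)C(C)(C)C2` differs from compound 2 in one place: (2-methoxyphenyl)carbamoyl in place of ethyl on an oxygen on an aromatic ring. For the measured compounds named here, only one single-point step is available among the measured compounds, and it bears on this change because a number 41.8 percentage points lower from compound 2 to compound 3 (beyond the scatter) also enlarges what is attached through the same aromatic oxygen of compound 2, turning a sizeable inhibition into a modest one. Going by the values given here, no measured step introduces a (2-methoxyphenyl)carbamoyl group anywhere, so the exact size of the change is open; what is known is that the one enlargement made at this oxygen was large and downward, and that the remaining measured compound also stands well below compound 2.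

In this assay the expected downward step is therefore estimated as a number 31.5 percentage points lower from compound 2 to compound 4 (beyond the scatter). Compound 4 is estimated at 35%, with a range from 15% to 58%.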

Compound 4, a percentage reported as inhibition, at one concentration (the size of the read-out at that concentration, not a potency): 71.1%
For compound 4 the middle estimate is 36.1 percentage points below the measured one, and the stated range ends below it.
By their numbers in this assay, from the lowest: compounds 3 and 1 (each within the scatter of the next); then compounds 2 and 4 (each within the scatter of the next).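

In this assay, the change at this oxygen gives a number 4.6 percentage points higher from compound 2 to compound 4 (within the scatter), so a (2-methoxyphenyl)carbamoyl group, with its 11 heavy atoms and one six-membered aromatic ring, is accommodated here with no change beyond the scatter. Set beside a number 41.8 percentage points lower from compound 2 to compound 3 (beyond the scatter), this shows that a large group on this oxygen does not in itself go with a lower reading: of the two enlargements at this place, only the one in compound 3 does, and compound 4 goes against any rule based on size alone. No measurement at hand accounts for the different outcomes of these two changes.

From the compounds shown here alone, it remains open whether the reading of compound 4 depends on the carbamoyl link, the aromatic ring or the methoxy group, and a phenylcarbamoyl, a dimethylcarbamoyl or a benzyl group on the same oxygen would begin to separate these parts. All readings also stand at a single concentration, leaving the relative potency of compound 2 and compound 4 undefined.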